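Shortening the amine side chain of compound 1

The source may report more compounds than this note shows. Statements on the series, on what has been measured and on what is new or still open speak of the compounds shown alone.

Compound 1, with the structure `CCCCN(CCC)c1nc(C)nc2c(-c3c(C)cc(N(C)C)nc3C)c(C)nn12`, gives 12.8 nM in an assay on cell membranes for displacement of a labelled ligand from corticotropin-releasing factor receptor 1 (Rattus norvegicus); on this read-out lower numbers stand for stronger inhibition and higher numbers for weaker inhibition. This is the highest number of the three measured compounds. Compound 2, `CCCCN(CC)c1nc(C)nc2c(-c3ccc(OC)nc3C)c(C)nn12`, gives 4.9 nM in this assay, a lower number than compound 1 and beyond the scatter; compound 3, `CCC(CC)Nc1nc(C)nc2c(-c3cnc(OC)cc3C)c(C)nn12`, gives 3 nM in this assay, lower still. Neither compound 2 nor compound 3 differs from compound 1 in only one place, so the values show only the spread of the series.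

Compound 4, `CCCCN(CC)c1nc(C)nc2c(-c3c(C)cc(N(C)C)nc3C)c(C)nn12`, has not yet been measured. It differs from compound 1 by hydrogen in place of methyl on a saturated chain carbon, two bonds along the chain from a nitrogen on an aromatic ring, that is, butyl(propyl)amino becomes butyl(ethyl)amino. For the measured compounds named here, no measured pair isolates this change, and compound 2 carries the shorter chain together with a different aromatic substituent, so no direction can be drawn from it. The removal of a single carbon from a saturated chain is expected to move the number little, within the scatter. Compound 4 is therefore estimated at 10 nM, in the range 4 nM to 25 nM, a step of a 1.3-fold lower number from compound 1 to compound 4 (0.11 log units; within the scatter) that is expected to stay inside the usual variation.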

Compound 4, half-maximal inhibitory concentration: 32.8 nM
For compound 4 the middle estimate is 3.3-fold (0.52 log units) below the measured one; the whole stated range lies below it.
By their numbers in this assay, from the lowest: compounds 3 and 2 (each within the scatter of the next); then compound 1; then compound 4.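

In this assay, the change from butyl(propyl)amino to butyl(ethyl)amino gives a 2.6-fold higher number from compound 1 to compound 4 (0.41 log units; beyond the scatter) and shows that this saturated chain position responds to the loss of a single carbon. For the compounds shown here, with the rest of the structure held the same, the propyl chain goes with the stronger inhibition, a reading that the earlier compounds, none of which differed in only one place, could not give. Nothing measured here accounts for this step.

A single pair cannot show whether the number would keep falling with a longer chain, such as pentyl, or how a cyclopropylmethyl group in place of the propyl would compare. From the compounds shown here alone, it also remains open whether the same shortening would have a similar effect on a compound carrying a methoxy group on its aromatic substituent.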